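Phenyl to 4-methylbenzyl on a second ring position

The compounds below may be only part of what the source reports. "The series", "measured", "known", "first", "only" and "open" are said of these compounds alone.

Compound 1 `Cc1ccc(Cc2nc3[nH]c(-c4ccc(Cl)cc4)cc(=O)n3n2)cc1`: 5440 nM
Compound 2 `O=c1cc(-c2ccc(Cl)cc2)[nH]c2nc(-c3ccccc3)nn12`: 2350 nM
Compound 3 `O=c1cc(-c2ccccc2)[nH]c2nc(Cc3ccc(Cl)cc3)nn12`: 1830 nM

In a functional assay on Cortical neurone cells (Mus musculus, strain C57BL/6), read by FLIPR and calcium flux, with a stated time of 8 min (on this read-out lower numbers stand for stronger inhibition and higher numbers for weaker inhibition), compound 3 gives 1830 nM, and compound 2 gives 2350 nM; the two lie within the scatter of each other. The step of a 2.3-fold higher number from compound 2 to compound 1 (0.36 log units; beyond the scatter) follows from the change (4-methylbenzyl in place of phenyl on an aromatic carbon). Compound 4 `Cc1ccc(Cc2cc(=O)n3nc(Cc4ccc(Cl)cc4)nc3[nH]2)cc1` carries the same kind of change, (4-methylbenzyl in place of phenyl on an aromatic carbon), but on the other ring of the core, so it is not the same change. The difference between the core of compound 3 and the core of compound 2 is not broken down here. In this assay compound 4 is expected to show a step of a 2.3-fold higher number from compound 3 to compound 4 (0.36 log units; beyond the scatter), resting on the weakening seen in a 2.3-fold higher number from compound 2 to compound 1 (0.36 log units; beyond the scatter), with wide uncertainty because the ring position differs. The estimate for compound 4 is 4200 nM, between 2000 nM and 9000 nM.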

Compound 4, half-maximal inhibitory concentration: 3020 nM
Beside the measured number, compound 4's estimate is 1.4-fold (0.14 log units) above it, and the stated range covers the measured number.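

In this assay, putting 4-methylbenzyl in place of phenyl gives a 1.7-fold higher number from compound 3 to compound 4 (0.22 log units; within the scatter), so this step lies within the scatter, whereas the earlier one lay beyond it. Even so, the two steps cannot be told apart, and the change carries over between these two cores with a similar size: the same change on two cores in this assay, a 2.3-fold higher number (0.36 log units; beyond the scatter) from compound 2 to compound 1 and a 1.7-fold higher number (0.22 log units; within the scatter) from compound 3 to compound 4, 1.4-fold (0.15 log units) apart, within the scatter of two such steps. Among the compounds shown here, this rests on only two pairs in one assay, and it shows neither how the change would behave on any other core nor what lies behind the size of either step.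

The compounds shown leave open how a different group at this ring carbon would behave. An amine, a carboxylic acid or a longer alkyl chain might not follow the same course.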